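Fluoro on the chlorophenyl ring of a piperidinyl-pyrazole isoxazole

A few compounds are considered here, and "the series" means these few. Any claim that something is new, unique, unknown or untested is made for them only; others in the source may bear on it.

Measured so far:
compound 1, `CN(Cc1cc(-c2ccccc2Cl)no1)C(=O)C1CCNCC1`, 41%
compound 2, `Clc1ccccc1-c1cc(-c2cnn(C3CCNCC3)c2)on1`, 38%
compound 3, `Cc1c(-c2cc(-c3ccccc3Cl)no2)cnn1C1CCNCC1`, 71%

In an assay on a protein complex for positive allosteric modulation of Neuronal acetylcholine receptor; alpha4/beta2 (Homo sapiens) (a lower number here means a smaller maximal response, a higher number a larger maximal response), compound 2 stands lowest of the three numbers. Its nearest neighbour is compound 1, whose value lies within the scatter of it, so the two cannot be ordered. Compound 3 stands apart: a number 33 percentage points higher from compound 2 to compound 3 (beyond the scatter), a methyl in place of hydrogen on an aromatic carbon.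

Compound 4, `Fc1ccc(Cl)c(-c2cc(-c3cnn(C4CCNCC4)c3)on2)c1`, differs from compound 2 in one place: fluoro in place of hydrogen on an aromatic carbon

Going by the values given here, no measured step touches the 2-chlorophenyl ring, so nothing bears directly on this change. Among the compounds with values here, the only step known, from compound 2 to compound 3, sits on another ring and concerns a methyl group, not a fluoro. The gap between compound 2 and compound 1 is within the scatter and tells no direction. The account therefore expects for compound 4 no step beyond the scatter in this assay, with the remaining uncertainty spread to both sides: a number 6 percentage points higher from compound 2 to compound 4 (within the scatter).

The estimate for compound 4 in this assay is 44%, with a range from 26% to 68%.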

Compound 4, largest response reached (reported as efficacy), in percent of the reference or control that the assay uses: 29%
Compound 4: the middle estimate sits 15 percentage points above what was measured; measured number inside the range.
By their numbers in this assay, from the lowest: compounds 4, 2 and 1 (each within the scatter of the next, the first and the last beyond it); then compound 3.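

This is the only step shown on the 2-chlorophenyl ring: in this assay, the change to 2-chloro-5-fluorophenyl gives a number 9 percentage points lower from compound 2 to compound 4 (within the scatter), so this fluoro, para to the chloro group and meta to a large group, cannot be told apart from hydrogen in this read-out. The methyl change on the other ring gave a number 33 percentage points higher from compound 2 to compound 3 (beyond the scatter), so of the two single changes shown, only that one moves the maximal response beyond the scatter. No measurement is available that would explain the outcome of the fluoro change.

The compounds shown leave open whether this fluoro would also stay within the scatter when combined with the methyl of compound 3, where the response starts from a higher number. They also leave open whether a larger group at the same place, such as methoxy, trifluoromethyl or an amine, would shift the response, and whether fluoro at another carbon of this ring would behave as it does in compound 4.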